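This account rests on a few compounds, and the source may have more. Where it says the series, first, only, none or still open, it means among the compounds named here.

Among the measured compounds shown here, only one number exists so far for this small set of compounds. In a functional assay on KB cells (Homo sapiens) for inhibition, read by MTT assay, with a stated time of 24 h, tested at 1 ug/mL (a higher number here means more inhibition of growth at the concentration tested, a lower number less inhibition of growth), compound 1 (`O=C(CCCCC(S)CCS)Nc1ccccc1`) gives 11.6% of inhibition, a single reading at one concentration. In this assay compound 2 (`O=C(CCCCC(S)CCS)Nc1cccc(C(F)(F)F)c1`) is reported as "not active" (no number reported) with no figure attached, so it has no place on the numerical scale and its distance from compound 1 cannot be stated as a step. The change under consideration leads to compound 3 (`Cc1cccc(NC(=O)CCCCC(S)CCS)c1`), which has not yet been measured. It is methyl in place of trifluoromethyl on an aromatic carbon and amounts to methyl in place of trifluoromethyl on an aromatic carbon. For the measured compounds named here, no measured pair shows what this exchange does. Only a small upward step from compound 2 is therefore expected in this assay, perhaps none beyond the usual scatter, and the expectation leans on compound 1 at 11.6% as the sole numerical reference. In this assay compound 3 is expected at 10% (estimated range 0% to 25%) and may also be reported without a number.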

Compound 3, percent growth inhibition at one concentration: 3.31%
Estimate against measurement, compound 3: 6.7 percentage points above; the measured number falls inside the stated range.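

In this assay compound 2, with trifluoromethyl on the aromatic carbon meta to a large group, is reported as "not active", whereas compound 3, with methyl at that place, gives 3.31% as a number, so the exchange turns a report without a figure into a reading, although the step between these two cannot be read. Among the compounds shown here, the first readable step at this position is methyl in place of hydrogen, a number 8.3 percentage points lower from compound 1 to compound 3 (within the scatter), and it does not separate the two compounds in this single-concentration read-out. Nothing measured for these compounds bears on why the readings fall as they do.

The compounds shown leave open whether any group on this aromatic carbon can move the reading beyond the scatter, as an amine, a chlorine atom or a methoxy group at the same place might or might not. They also leave open how the reading responds to changes elsewhere on the shared core, such as a longer chain on the amide carbonyl.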